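The source may report more compounds than this note shows. Statements on the series, on what has been measured and on what is new or still open speak of the compounds shown alone.

Compound 1 `CC(Cn1ccc(-c2ccc(C#N)c(Cl)c2)n1)C(=O)Nc1cc[nH]n1`: > 30000 nM
Compound 2 `C[C@@H](Cn1ccc(-c2ccc(C#N)c(Cl)c2)n1)NS(=O)(=O)c1cccnc1`: 2450 nM

Going by the values given here, in a functional assay on VCaP cells (Homo sapiens) for antiproliferative activity, read by CCK-8 assay, with a stated time of 6 days (on this read-out higher numbers stand for weaker inhibition and lower numbers for stronger inhibition), compound 2 gives the only true number so far, 2450 nM. The entry for compound 1, > 30000 nM, is a limit of the assay and not a number.

Compound 3 `C[C@@H](Cn1ccc(-c2ccc(C#N)c(Cl)c2)n1)Nc1ncccn1` has pyrimidin-2-yl in place of (pyridin-3-yl)sulfonyl on an amine nitrogen. Among the compounds with values here, no measured pair of closely related compounds shows what such a swap does in this assay, so no shift in either direction beyond the usual scatter is expected. The expected step, a 1.2-fold higher number from compound 2 to compound 3 (0.09 log units; within the scatter), is therefore small and uncertain. For compound 3 the estimated value is 3000 nM, with an expected range of 700 nM to 15000 nM.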

Compound 3, half-maximal inhibitory concentration: 480 nM
Compound 3: middle estimate off by 6.3-fold (0.80 log units), on the high side; the measured number lies below the stated range.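

Going by these compounds alone, at this amine nitrogen a sulfonyl group is not required for activity: pyrimidin-2-yl in place of (pyridin-3-yl)sulfonyl gives a 5.1-fold lower number from compound 2 to compound 3 (0.71 log units; beyond the scatter) in this assay, the first measured step at this position. The entering group is also the smaller one, with 6 heavy atoms against 9. Nothing measured here explains this gain.

The swap removes the sulfonyl link and changes the ring at once, so the two changes cannot be told apart. From the compounds shown here alone, how a phenyl ring joined directly to this nitrogen would compare remains open.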